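Moving Two Chlorines on a Phenyl Ring

The compounds below may be only part of what the source reports. "The series", "measured", "known", "first", "only" and "open" are said of these compounds alone.

In a functional assay on MCF7 cells (Homo sapiens) for cytotoxicity, read by MTT assay, with a stated time of 72 h (on this read-out lower numbers stand for stronger inhibition and higher numbers for weaker inhibition), compound 1 `COc1ccc(/C=C2\CCC/C(=C\c3cccc(Cl)c3)C2=O)cc1OC` gives 6000 nM, compound 2 `COc1ccc(/C=C2\CCC/C(=C\c3ccc(OC)c(OC)c3)C2=O)cc1` gives 7800 nM and compound 3 `COc1ccc(/C=C2\CCC/C(=C\c3ccc(Cl)cc3Cl)C2=O)cc1OC` gives 16200 nM, the highest number of the three and so the weakest inhibition. Compound 4 `COc1ccc(/C=C2\CCC/C(=C\c3cc(Cl)cc(Cl)c3)C2=O)cc1OC` has the same atoms, joined differently, with 3,5-dichlorophenyl in place of 2,4-dichlorophenyl (3,5-dichlorophenyl in place of 2,4-dichlorophenyl on a double-bonded chain carbon bound to a double-bonded ring carbon). Two measured changes bear on this: a 2.7-fold higher number from compound 1 to compound 3 (0.43 log units; beyond the scatter) and a 2.1-fold higher number from compound 2 to compound 3 (0.32 log units; beyond the scatter). Both introduced 2,4-dichlorophenyl, and both were modest. The third, a 1.3-fold higher number from compound 1 to compound 2 (0.11 log units; within the scatter), stays within the scatter. For the measured compounds named here, no measured compound carries 3,5-dichlorophenyl, so the expectation is loose: a modest move to a lower number in this assay. The estimated change is a 2.2-fold lower number from compound 3 to compound 4 (0.33 log units; beyond the scatter). The expected value for compound 4 is 7500 nM, within a range from 3000 nM to 18000 nM.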

Compound 4, half-maximal inhibitory concentration: 3800 nM
Beside the measured number, compound 4's estimate is 2.0-fold (0.30 log units) above it, and the stated range covers the measured number.
By their numbers in this assay, from the lowest: compounds 4, 1 and 2 (each within the scatter of the next, the first and the last beyond it); then compound 3.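

Moving the two chlorines, with no atom gained or lost, gives a 4.3-fold lower number from compound 3 to compound 4 (0.63 log units; beyond the scatter) in this assay and so shows that their placement on this ring can alone shift the number. Putting 3,5-dichlorophenyl in place of 4-methoxyphenyl gives a 2.1-fold lower number from compound 2 to compound 4 (0.31 log units; beyond the scatter) while chloro in place of hydrogen on an aromatic carbon gives a 1.6-fold lower number from compound 1 to compound 4 (0.20 log units; within the scatter) and so adds no clear change. Nothing available here explains why the placement of the chlorines matters. From the compounds shown here alone, whether a phenyl ring carrying two fluorines or an amine at this place would match 3,5-dichlorophenyl remains open.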